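Removing a Fluoro Group from Compound 3

The compounds below may be only part of what the source reports. "The series", "measured", "known", "first", "only" and "open" are said of these compounds alone.

Compound 3 `Cc1nc(-c2cccc(F)c2)c(C(=O)N2CCN(c3cc(Cl)cc(Cl)c3)CC2)o1` gives 41.7 nM in a functional assay on HL-60 cells (Homo sapiens) for inhibition, read by MTT assay, with a stated time of 72 h (on this read-out higher numbers stand for weaker inhibition and lower numbers for stronger inhibition), the second highest of three numbers measured. Among the compounds with values here, its nearest neighbour is compound 1 `COc1cc(OC)cc(N2CCN(C(=O)c3oc(C)nc3-c3cccc(F)c3)CC2)c1`, which gives 28.2 nM; the only single-point step measured, a 1.5-fold higher number from compound 1 to compound 3 (0.17 log units; within the scatter), lies within the scatter. Compound 2 `Cc1nc(-c2ccccc2)c(C(=O)N2CCN(c3c(C)cccc3C)CC2)o1` differs from compound 3 in several places. In this assay compound 2 gives 146 nM, which lies beyond the scatter from the number of compound 3.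

Compound 4 `Cc1nc(-c2ccccc2)c(C(=O)N2CCN(c3cc(Cl)cc(Cl)c3)CC2)o1` is not yet measured. It differs from compound 3 by hydrogen in place of fluoro on an aromatic carbon. Within the data shown here, no measured step isolates this change: the one step known concerns the aryl on the amine nitrogen, not the fluorophenyl. Compound 2 also lacks the fluoro but changes elsewhere too, so its higher number cannot be attributed to the fluoro alone. A modest step is therefore expected, a 1.6-fold higher number from compound 3 to compound 4 (0.19 log units; within the scatter), leaning towards a slightly higher number, but one that may well stay within the scatter. Compound 4 is estimated at 65 nM, with a range from 25 nM to 170 nM.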

Compound 4, half-maximal inhibitory concentration: 41.8 nM
For compound 4 the middle estimate is 1.6-fold (0.19 log units) above the measured one, within the range that was stated.
By their numbers in this assay, from the lowest: compounds 1, 3 and 4 (each within the scatter of the next); then compound 2.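

In this assay, hydrogen in place of fluoro on an aromatic carbon gives a 1.0-fold higher number from compound 3 to compound 4 (0.00 log units; within the scatter), so in this pair, with 3,5-dichlorophenyl on the amine nitrogen, the 3-fluorophenyl and phenyl compounds cannot be told apart. With phenyl held constant, 3,5-dichlorophenyl in place of 2,6-dimethylphenyl on an amine nitrogen in a ring gives a 3.5-fold lower number from compound 2 to compound 4 (0.54 log units; beyond the scatter), which isolates a step beyond the scatter that the earlier comparison of compound 2 with compound 3 could not separate from the fluoro. No measurement shown here accounts for either step.

The compounds shown leave open whether the fluoro makes as little difference when the aryl on the amine nitrogen is 3,5-dimethoxyphenyl or 2,6-dimethylphenyl. They also leave open how a methoxy group, an amine or a carboxylic acid on the same aromatic carbon would read in this assay.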